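The source may hold more compounds than are shown below. What is called first, only, known or untested is meant among the compounds shown, and "the series" means these compounds.

Working notes on the sulfone series. In an assay on isolated protein for displacement of a labelled ligand from 5-hydroxytryptamine receptor 6 (Homo sapiens) (on this read-out lower numbers stand for stronger inhibition and higher numbers for weaker inhibition), compound 1 `CN(C)CC1CCCc2cc(S(=O)(=O)c3ccccc3)ccc21` gives 0.0631 nM, compound 2 `N#Cc1cccc(S(=O)(=O)c2ccc3c(c2)CCC[C@H]3C=N)c1` gives 0.501 nM, and compound 3 `CNS(=O)(=O)NC[C@@H]1CCCc2cc(S(=O)(=O)c3cccc(F)c3)ccc21` gives 1 nM. Compound 3 carries the highest number of the three: compound 1 sits lower by a margin beyond the scatter, while the values of compound 2 and compound 3 lie within the scatter of one another. Compound 4 `O=S(=O)(c1cccc(F)c1)c1ccc2c(c1)CCC[C@H]2CN1CC(O)C1` differs from compound 3 by 3-hydroxyazetidin-1-yl in place of (methylsulfamoyl)amino on a saturated chain carbon bound to a saturated ring carbon. Within the data shown here, no pair of measured compounds isolates this change, so nothing directly anchors the step. Because compound 1 gives 0.0631 nM with an amine on the same saturated chain carbon, a modest move toward lower numbers is expected; the expected step is a 2.5-fold lower number from compound 3 to compound 4 (0.40 log units; beyond the scatter). Compound 4 is estimated at 0.4 nM, within 0.1 nM to 2 nM.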

Compound 4, inhibition constant: 0.1 nM
Beside the measured number, compound 4's estimate is 4.0-fold (0.60 log units) above it; measured number inside the range.
By their numbers in this assay, from the lowest: compounds 1 and 4 (each within the scatter of the next); then compounds 2 and 3 (each within the scatter of the next).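

In this assay, the group on a saturated chain carbon bound to a saturated ring carbon clearly moves the number: 3-hydroxyazetidin-1-yl in place of (methylsulfamoyl)amino gives a 10-fold lower number from compound 3 to compound 4 (1.00 log units; beyond the scatter). The position therefore accepts a four-membered ring carrying a hydroxyl in place of the open chain, with no loss in this read-out. Nothing available bears on the cause of this step.

As far as these compounds go, whether the step comes from the ring or from its hydroxyl remains open. So does the outcome with unsubstituted azetidine or pyrrolidine on the same carbon of compound 4.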